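Bromo for fluoro carried onto the propyl core

The source may report more compounds than this note shows. Statements on the series, on what has been measured and on what is new or still open speak of the compounds shown alone.

Compound 2 `Cc1nc2ccccc2c(=O)n1/N=C/c1ccc(Oc2ccc(F)cc2)cc1` gives 4.21 in a physicochemical assay for lipophilicity, in phosphate buffer, measured as octanol-water partition; on this read-out higher numbers stand for higher lipophilicity and lower numbers for lower lipophilicity. Compound 1 `Cc1nc2ccccc2c(=O)n1/N=C/c1ccc(Oc2ccc(Br)cc2)cc1` gives 4.64 in this assay, and compound 3 `CCCc1nc2ccccc2c(=O)n1/N=C/c1ccc(Oc2ccc(F)cc2)cc1` gives 5.22 in this assay, the highest of the three, with both steps to it beyond the scatter. The change bromo in place of fluoro on an aromatic carbon made a step of a number 0.43 log units higher from compound 2 to compound 1 (beyond the scatter). The two cores differ by ethyl in place of hydrogen on a saturated chain carbon bound to an aromatic carbon, which made a step of a number 1.01 log units higher from compound 2 to compound 3 (beyond the scatter). Compound 4 `CCCc1nc2ccccc2c(=O)n1/N=C/c1ccc(Oc2ccc(Br)cc2)cc1` is not yet measured in this assay. It differs from compound 3 by bromo in place of fluoro on an aromatic carbon, the same change and at the same place as from compound 2 to compound 1, now on the core of compound 3. Among the compounds with values here, for compound 4 a step of a number 0.43 log units higher from compound 3 to compound 4 (beyond the scatter) is expected, because a number 0.43 log units higher from compound 2 to compound 1 (beyond the scatter) is the one measured instance of this change. Compound 4 is estimated at 5.65, between 5.35 and 5.95.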

Compound 4, partition coefficient: 5.88
Estimate against measurement, compound 4: 0.23 log units below, and the stated range covers the measured number.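

In this assay, bromo in place of fluoro on an aromatic carbon gives a number 0.66 log units higher from compound 3 to compound 4 (beyond the scatter), against a number 0.43 log units higher from compound 2 to compound 1 (beyond the scatter) on the other core, so the change carries over in direction, with both steps beyond the scatter. Ethyl in place of hydrogen gives a number 1.24 log units higher from compound 1 to compound 4 (beyond the scatter) with bromo present, against a number 1.01 log units higher from compound 2 to compound 3 (beyond the scatter) with fluoro present. This is a single pair of cores, which does not establish a fixed step size for other cores, and nothing at hand accounts for the size of any of these steps.

On these data alone, whether the change behaves alike with a longer chain on the shared core, or with an amine or a carboxylic acid there, stays open. Chloro at the same place also stays open.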